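Biaryl extension of the anilide phenyl in the boron series

The compounds below may be only part of what the source reports. "The series", "measured", "known", "first", "only" and "open" are said of these compounds alone.

Compound 2 `O=C(CCc1cccc2c1B(O)OC2)Nc1ccccc1` gives the lowest number shown in a functional assay on MDA-MB-231 cells (Homo sapiens) for antiproliferative activity, read by MTT assay, with a stated time of 72 h (on this read-out lower numbers stand for stronger inhibition and higher numbers for weaker inhibition), 230 nM. Compound 3 `O=C(CCc1cccc2c1B(O)OC2)Nc1ccc(Cl)cc1` gives 3600 nM in this assay. For compound 1 `CCNC(=O)CCc1cccc2c1B(O)OC2` the result in this assay is a limit of the assay, > 100000 nM. Compound 4 `CSc1cccc(-c2cccc(NC(=O)CCc3cccc4c3B(O)OC4)c2)c1` is not yet measured; it differs from compound 2 by 3-(methylsulfanyl)phenyl in place of hydrogen on an aromatic carbon. The step that bears on this change is a 16-fold higher number from compound 2 to compound 3 (1.19 log units; beyond the scatter), a substitution on the same phenyl on the amide-type nitrogen; the step of an at least 430-fold lower number from compound 1 to compound 2 (2.63 log units; beyond the scatter) shows how strongly that amide substituent sets the number. A larger substituent on that phenyl is therefore expected to raise the number in this assay, with the size uncertain. Compound 4 is expected to give 800 nM, between 150 nM and 5000 nM. The expected step is a 3.5-fold higher number from compound 2 to compound 4 (0.54 log units; beyond the scatter).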

Compound 4, half-maximal inhibitory concentration: 150 nM
For compound 4 the middle estimate is 5.3-fold (0.73 log units) above the measured one; the range from low to high includes it.
By their numbers in this assay, from the lowest: compounds 4 and 2 (each within the scatter of the next); then compound 3. At a limit, above all of these: compound 1.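

In this assay the phenyl on the amide-type nitrogen carries 3-(methylsulfanyl)phenyl, a group of 8 heavy atoms, with a 1.5-fold lower number from compound 2 to compound 4 (0.19 log units; within the scatter) on the record, so a large group at this place leaves the number within the scatter of compound 2. Added bulk alone therefore does not set the number on this phenyl, and compound 3 goes the other way with a 16-fold higher number from compound 2 to compound 3 (1.19 log units; beyond the scatter) for a single chloro. Nothing measured here accounts for the difference between these two steps.

Still open, going by these compounds, is whether an amine or a carboxylic acid in place of the methylsulfanyl group keeps the number in this assay. Also open, on these data alone, is how the same 3-(methylsulfanyl)phenyl group behaves at other carbons of the anilide phenyl.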